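Swapping a dichlorophenyl amide partner for a small ring

The compounds below may be only part of what the source reports. "The series", "measured", "known", "first", "only" and "open" are said of these compounds alone.

Compound 1 `COc1ccc(C(=O)Nc2cccc(Cl)c2Cl)cc1OC1CCCC1` is an amide built on a shared core that carries a methoxy group and a cyclopentyl ether, with a 2,3-dichlorophenyl group on the amide-type nitrogen. In an assay on isolated protein for inhibition of phosphodiesterase 4A (Sus scrofa) (on this read-out higher numbers stand for weaker inhibition and lower numbers for stronger inhibition), compound 1 gives only a limit, > 200000 nM. Two other compounds share this core and the same amide link. Compound 2 `COc1ccc(C(=O)Nc2c(F)c(F)nc(F)c2F)cc1OC1CCCC1` gives 550 nM in this assay. Compound 3 `COc1ccc(C(=O)Nc2c(Cl)c(F)nc(F)c2Cl)cc1OC1CCCC1` gives 20 nM in this assay. The move from compound 1 to compound 4 is a single change on the amide-type nitrogen: a group of 7 heavy atoms (5 carbon, 1 nitrogen, 1 oxygen; one five-membered non-aromatic ring with 2 hetero atoms) in place of a group of 8 heavy atoms (6 carbon, 2 chlorine; one six-membered aromatic ring of carbon only), on an amide-type nitrogen. Compound 4 is `COc1ccc(C(=O)NC2(C)C=C(C)ON2)cc1OC1CCCC1`. Among the measured compounds shown here, no measured pair shows a change of this kind, so the size of the step rests on expectation alone. Because compound 1 sits at the limit (the limit of > 200000 nM in this assay, at which 1 of the 3 values shown sits), any number that the assay can report for compound 4 would count as stronger inhibition, although the entering group is a non-aromatic ring unlike the substituted aromatic rings of compound 2 and compound 3. Compound 4 is expected to give about 20000 nM, within a range from 2000 nM to 200000 nM. The step from compound 1 to compound 4 implied by this estimate is an at least 10-fold lower number from compound 1 to compound 4 (1.00 log units; beyond the scatter), an expectation rather than a measurement.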

Compound 4, half-maximal inhibitory concentration: 450 nM
The estimate for compound 4 lay 44-fold (1.65 log units) above the measured number; the measured number lies below the stated range.
By their numbers in this assay, from the lowest: compound 3; then compounds 4 and 2 (each within the scatter of the next). At a limit, above all of these: compound 1.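

On the amide-type nitrogen, the change from the 2,3-dichlorophenyl group to a five-membered non-aromatic ring with 2 hetero atoms gives in this assay an at least 440-fold lower number from compound 1 to compound 4 (2.64 log units; beyond the scatter) and shows that, among the compounds here, measurable inhibition does not need an aromatic ring at this place. The true size of this step cannot be read, because compound 1 gives only a limit of the assay: the limit of > 200000 nM in this assay, at which 1 of the 4 values shown sits. Compound 4 at 450 nM and compound 2 at 550 nM lie within the scatter of each other, while compound 3 gives 20 nM as the lowest number, so the non-aromatic ring matches one of the substituted aromatic rings but not the other.

The compounds shown do not separate which part of the entering group matters: the ring itself, its double bond, or its hydrogen-bond donor and acceptors. A cyclohexyl group, built of carbon only, or a piperidine ring on the same nitrogen would be needed to begin pulling these apart.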